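This account rests on a few compounds, and the source may have more. Where it says the series, first, only, none or still open, it means among the compounds named here.

Of the compounds shown here, three built on a shared core have been measured so far. In a functional assay on HCT-15 cells (Homo sapiens) (a lower number here means that less compound is needed, a higher number that more compound is needed for the effect), compound 1 (`COc1cc(OC)c(C2OC(c3ccc(N(C)C)cc3)=NN2C(C)=O)c(OC)c1`) gives 71 uM and compound 2 (`COc1ccc(C2OC(c3ccc(N(C)C)cc3)=NN2C(C)=O)c(OC)c1OC`) gives 7.5 uM. Compound 3 (`CCOC(=O)C(=O)N1N=C(c2ccc(N(C)C)cc2)OC1c1cc(OC)c(OC)c(OC)c1`) gives 45 uM. That places compound 3 within the scatter of compound 1, while compound 2 lies beyond the scatter on the side of the lower number, so less of it is needed for the effect.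

The next compound to be tested is compound 4 (`COc1cc(C2OC(c3ccc(N(C)C)cc3)=NN2C(=O)CN=[N+]=[N-])cc(OC)c1OC`). It has azidomethyl in place of ethoxycarbonyl on a carbonyl carbon, and the rest of compound 3 stays as it is: azidomethyl in place of ethoxycarbonyl on a carbonyl carbon.

Among the compounds with values here, no two measured compounds differ in just one place, so the data offer no direct measure of what this exchange does. The starting point for the expectation is therefore compound 3 at 45 uM. The spread from compound 2 at 7.5 uM to compound 1 at 71 uM shows how far this small set can move, and it argues for a wide range.

The expected change is small and towards a lower number, a 1.5-fold lower number from compound 3 to compound 4 (0.18 log units; within the scatter), which would not go beyond the scatter. For compound 4 the estimated value is 30 uM, with an expected range from 9 uM to 90 uM.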

Compound 4, concentration for half-maximal effect: 0.15 uM
For compound 4 the middle estimate is 200-fold (2.30 log units) above the measured one; measured number outside the range, below it.
By their numbers in this assay, from the lowest: compound 4; then compound 2; then compounds 3 and 1 (each within the scatter of the next).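

In this assay, within the data shown here, the exchange of ethoxycarbonyl for azidomethyl on a carbonyl carbon gives a 300-fold lower number from compound 3 to compound 4 (2.48 log units; beyond the scatter) and is the first step in this set that isolates a single place, showing that this position, on a carbonyl carbon whose other neighbour is an amide-type nitrogen in a ring, can move the number by a large margin. The step comes with almost no change in the count of heavy atoms, 5 leaving and 4 entering, while the make-up differs: carbon and oxygen leave, and one carbon with three nitrogens enters. Nothing measured here speaks to why the step is so large.

With only this one step, the compounds shown do not separate the contribution of the azide from that of the methylene carbon carrying it, a question that a plain methyl, an aminomethyl or a chloromethyl group on the same carbonyl carbon would address. As far as these compounds go, whether azidomethyl gives a step of similar size on the cores of compound 1 and compound 2 also stays open.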